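Methylsulfonyl in place of ethoxy: working notes

The source may report more compounds than this note shows. Statements on the series, on what has been measured and on what is new or still open speak of the compounds shown alone.

Values in a functional assay on HL-60 cells (Homo sapiens) for activation, read by flow cytometry, with a stated time of 4 days (a lower number here means that less compound is needed, a higher number that more compound is needed for the effect), so far
- compound 1 `COc1ccc(-n2cnc3cnc(-c4ccc(F)cc4C)cc32)cc1` gives 6 nM
- compound 2 `CCOc1ccc(-n2cnc3cnc(-c4ccc(F)cc4C)cc32)cc1` gives 19 nM

Among the measured compounds shown here, of these two numbers, compound 2 stands highest at 19 nM in this assay so far. Compound 3 `Cc1cc(F)ccc1-c1cc2c(cn1)ncn2-c1ccc(S(C)(=O)=O)cc1` has methylsulfonyl in place of ethoxy on an aromatic carbon. For the measured compounds named here, the only measured step is a 3.2-fold higher number from compound 1 to compound 2 (0.50 log units; beyond the scatter) and it is modest but beyond the scatter. Going by the values given here, that step changes only the ethoxy chain by one methyl, and no measured compound carries methylsulfonyl, so it is a weak guide. A larger move to a higher number is expected, estimated as a 4.7-fold higher number from compound 2 to compound 3 (0.68 log units; beyond the scatter) with wide uncertainty. In this assay compound 3 is expected at 90 nM (estimated range 20 nM to 400 nM).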

Compound 3, half-maximal effective concentration: > 30000 nM
Compound 3: no number, only a limit; the forecaster's own chance of this, stated with the estimate: 5%; at least 330-fold (2.52 log units) between middle value and limit.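

Compound 3 reaches only a limit of the assay in this assay: the limit of > 30000 nM in this assay, at which 1 of the 3 values shown sits.

On this aromatic carbon, para to a large group, methylsulfonyl gives an at least 1500-fold higher number from compound 2 to compound 3 (3.19 log units; beyond the scatter) and an at least 5000-fold higher number from compound 1 to compound 3 (3.69 log units; beyond the scatter). The methoxy and ethoxy pair had shown only a modest difference, a 3.2-fold higher number from compound 1 to compound 2 (0.50 log units; beyond the scatter), so the position responds far more strongly to this exchange than to one added methyl on the chain.

On these data alone, whether the ether oxygen attached to the ring is what matters remains open. So does the outcome with an amine, a carboxylic acid or a longer chain on this carbon.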